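From 4-chlorophenyl to 3-chlorophenyl in compound 4

The source may hold more compounds than are shown below. What is called first, only, known or untested is meant among the compounds shown, and "the series" means these compounds.

In a functional assay on DU-145 cells (Homo sapiens) for cytotoxicity, in the presence of a further agent that is not named here (on this read-out higher numbers stand for weaker inhibition and lower numbers for stronger inhibition), compound 1 `Clc1ccc(-c2cc(-c3ccc(Cl)o3)cc(-c3ccsc3)n2)cc1` gives 19500 nM as its reading, compound 2 `Clc1ccc(-c2cc(-c3ccoc3)cc(-c3ccsc3)n2)cc1` gives 37600 nM and compound 3 `Clc1ccc(-c2cc(-c3ccc(Cl)o3)cc(-c3cccs3)n2)cc1` gives 19200 nM on the same scale. Compound 1 stands among these numbers with both of its steps inside the usual scatter, so it cannot be ranked against either of the other two.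

Compound 4 `Clc1cccc(-c2cc(-c3ccc(Cl)o3)cc(-c3ccsc3)n2)c1` has the same atoms as compound 1, joined differently, and the change is 3-chlorophenyl in place of 4-chlorophenyl on an aromatic carbon in this one place. That group sits on an aromatic carbon of a six-membered aromatic ring with 1 nitrogen, next to the ring nitrogen.

For the measured compounds named here, no measured compound varies this group, so the evidence is indirect. Two steps made elsewhere on the molecule bear on it: a 1.9-fold higher number from compound 1 to compound 2 (0.29 log units; within the scatter) with furan-3-yl in place of 5-chlorofuran-2-yl, and a 1.0-fold lower number from compound 1 to compound 3 (0.01 log units; within the scatter) with thiophen-2-yl in place of thiophen-3-yl on an aromatic carbon. Both lie within the scatter. No step beyond the scatter is therefore expected in this assay for this swap, in either direction. The expected change is a 1.0-fold higher number from compound 1 to compound 4 (0.01 log units; within the scatter) and it stays within the scatter. For compound 4 the estimated value is 20000 nM with 10000 nM to 40000 nM as its expected range.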

Compound 4, half-maximal inhibitory concentration: 10400 nM
For compound 4 the middle estimate is 1.9-fold (0.28 log units) above the measured one, and the stated range covers the measured number.
By their numbers in this assay, from the lowest: compounds 4, 3, 1 and 2 (each within the scatter of the next, the first and the last beyond it).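

For the compounds shown here, this is the first direct look at the chlorophenyl group next to the ring nitrogen, and in this assay moving the chlorine from 4-chlorophenyl to 3-chlorophenyl gives a 1.9-fold lower number from compound 1 to compound 4 (0.27 log units; within the scatter) and so does not separate the two compounds. All three single changes around compound 1, at the 5-chlorofuran-2-yl group, the thiophen-3-yl group and now the 4-chlorophenyl group, therefore stay within the usual scatter of this read-out, and none of these three places yet stands out as one where a small change matters. Nothing measured here gives a reason for the reading of compound 4.

All the compounds shown keep a chlorine on this phenyl ring, so it remains open whether the ring needs a chlorine at all, and what a plain phenyl, a methoxy group or an amine there would do. On these data alone, it also remains open whether a larger change at this place, such as a carboxylic acid in place of the chlorine, would give a step beyond the scatter.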